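Moving the Chlorine on the Hydrazone Aryl Ring

A few compounds are considered here, and "the series" means these few. Any claim that something is new, unique, unknown or untested is made for them only; others in the source may bear on it.

Two compounds of this study carry a number in a functional assay on HepG2 cells (Homo sapiens) for inhibition, read by MTT assay, with a stated time of 72 h; on this read-out lower numbers stand for stronger inhibition and higher numbers for weaker inhibition. Compound 1 `CN(C(=O)NC(=O)c1ccc(F)c(F)c1)c1nc(C(F)(F)F)c(C(=O)N/N=C/c2ccc(C(F)(F)F)cc2)s1` gives 6.26 ug/mL. Compound 2 `Cc1nc(N(C)C(=O)NC(=O)c2c(F)cccc2F)sc1C(=O)N/N=C/c1ccc(Cl)cc1` gives only a limit, > 100 ug/mL. That value is the limit of the assay and not a measured number, and of the two values shown it is compound 2 that sits there (the limit of > 100 ug/mL in this assay, at which 1 of the 2 values shown sits). Compound 3 `Cc1nc(N(C)C(=O)NC(=O)c2c(F)cccc2F)sc1C(=O)N/N=C/c1ccccc1Cl` has not yet been measured. It differs from compound 2 in one place: 2-chlorophenyl in place of 4-chlorophenyl on a carbon with a double bond to nitrogen. Within the data shown here, no step between two measured compounds of this kind exists here, so the size of the step cannot be read off from earlier pairs and can only be guessed from where compound 2 stands. The step expected is a number no higher from compound 2 to compound 3 (the limit leaves the size open), a change that is not expected to go beyond the scatter in either direction. Compound 3 is therefore estimated at 100 ug/mL, with a range from 30 ug/mL to 300 ug/mL, and it may well again be reported only as a limit.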

Compound 3, half-maximal inhibitory concentration: > 100 ug/mL
Compound 3: only a limit was reported; the forecaster's own chance of this, stated with the estimate: 70%; the middle value sits exactly at the limit.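

In this assay, compound 2 and compound 3 are both reported only as a limit and not as a number, so no step can be read between them: the limit of > 100 ug/mL in this assay, at which 2 of the 3 values shown sit.

The compounds shown leave open whether 2-chlorophenyl in place of 4-chlorophenyl changes inhibition at all, and what actual number either compound would give.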